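The compounds below may be only part of what the source reports. "The series", "measured", "known", "first", "only" and "open" are said of these compounds alone.

Compound 1 `O=C(CSc1nncc2cncn12)c1ccccc1`: > 48000 nM
Compound 2 `Cc1nc(-c2ccccc2)n2c(S)nncc12`: > 48000 nM

In a functional assay for inhibition, with Homo sapiens as the target (a higher number here means a weaker inhibitor, a lower number a stronger inhibitor), compound 2 gives > 48000 nM, which is a limit of the assay rather than a measured number. In this assay compound 1 likewise gives only a limit, > 48000 nM. Both values sit at the limit of > 48000 nM in this assay, at which 2 of the 2 values shown sit, so compound 2 stands at the weak end of what has been seen. Compound 3 `C=CCSc1nncc2c(C)nc(-c3ccccc3)n12` differs from compound 2 by allyl in place of hydrogen on a sulfur. Going by the values given here, no measured step covers such a change here. The step of a number no higher from compound 2 to compound 3 (the limit leaves the size open) is expected to stay within the scatter, with no gain beyond it. Compound 3 is therefore expected to give 48000 nM, estimated between 20000 nM and 150000 nM.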

Compound 3, half-maximal inhibitory concentration: > 48000 nM
Compound 3: only a limit was reported; the forecaster's own chance of this, stated with the estimate: 80%; the middle value sits exactly at the limit.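

Compound 2 and compound 3 each give only a limit in this assay, so no step between them can be read: the limit of > 48000 nM in this assay, at which 3 of the 3 values shown sit. The compounds shown leave open how strong any of them truly is, and whether allyl in place of hydrogen on a sulfur changes that.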